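A few compounds are considered here, and "the series" means these few. Any claim that something is new, unique, unknown or untested is made for them only; others in the source may bear on it.

Measured compounds:
compound 1, `O=C(COc1ccc2oc(-c3ccccc3)cc(=O)c2c1)Nc1ccc(F)cc1`, 470 nM
compound 2, `COc1ccc(NC(=O)COc2ccc3oc(-c4ccccc4)cc(=O)c3c2)cc1`, 3010 nM
compound 3, `O=C(COc1ccc2c(=O)cc(-c3ccccc3)oc2c1)Nc1ccc(F)cc1`, 6410 nM

The study concerns three measured compounds and a fourth that has not yet been tested. In a functional assay on MT2 cells (Homo sapiens) for antiproliferative activity, read by MTT assay, with a stated time of 72 h (on this read-out lower numbers stand for stronger inhibition of growth and higher numbers for weaker inhibition of growth), compound 1 gives 470 nM, and compound 2 gives 3010 nM. The difference between the two is a single substitution, (methoxy in place of fluoro on an aromatic carbon), and it made a step of a 6.4-fold higher number from compound 1 to compound 2 (0.81 log units; beyond the scatter).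

Compound 3 is built from the same atoms as compound 1, joined differently; the difference between the two cores is not broken down here. In this assay compound 3 gives 6410 nM, the highest of the three numbers, above compound 2 and well above compound 1.

Compound 4, `COc1ccc(NC(=O)COc2ccc3c(=O)cc(-c4ccccc4)oc3c2)cc1`, stands to compound 3 as compound 2 stands to compound 1: the change is methoxy in place of fluoro on an aromatic carbon, the same change seen between compound 1 and compound 2, made on the core of compound 3 instead. Among the four compounds this change occurs twice in all. Within the data shown here, the only guide to its effect is the single measured instance, in which the step from compound 1 to compound 2 was a 6.4-fold higher number from compound 1 to compound 2 (0.81 log units; beyond the scatter). Since the core of compound 3 already gives the weakest growth inhibition of the set, a number of the same direction is expected for compound 4, with the step estimated at a 2.8-fold higher number from compound 3 to compound 4 (0.45 log units; beyond the scatter). On that basis compound 4 is expected to give about 18000 nM in this assay, with a likely range from 6000 nM to 50000 nM; a weak compound of this kind may also return only a limit of the assay rather than a number.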

Compound 4, concentration for 50% growth inhibition: 6700 nM
Estimate against measurement, compound 4: 2.7-fold (0.43 log units) above; the measured number falls inside the stated range.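

In this assay, putting methoxy in place of fluoro on the core of compound 3 gave a 1.0-fold higher number from compound 3 to compound 4 (0.02 log units; within the scatter), so on this core the two groups cannot be told apart. The change therefore did not carry from one core to the other with the same size, and the two steps differ by more than their scatter: the same change on two cores in this assay, a 6.4-fold higher number (0.81 log units; beyond the scatter) from compound 1 to compound 2 and a 1.0-fold higher number (0.02 log units; within the scatter) from compound 3 to compound 4, 6.1-fold (0.79 log units) apart, beyond the scatter of two such steps. Among these compounds, this shows that, for this one change in this one assay, a step measured on the core of compound 1 does not predict the step on the core of compound 3, but with only two pairs it does not show why, nor whether other changes at this place would depend on the core in the same way.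

Still open, from the compounds shown here alone, is whether other groups in place of fluoro on this aromatic carbon, such as chloro, a nitrile or an amine, would give a large step on one core and none on the other, as methoxy did. Also open, going by these compounds, is whether the same contrast would survive with a longer chain carrying the amide, or with a carboxylic acid in place of the 4-fluorophenylamino part.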